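Taking the fluoro group off compound 2

The compounds below may be only part of what the source reports. "The series", "measured", "known", "first", "only" and "open" are said of these compounds alone.

Compound 2 `Cc1nc(-c2ccccc2F)c(C(=O)N2CCN(c3cc(Cl)cc(Cl)c3)CC2)o1` stands highest of the three measured compounds in an ADME assay on microsomes from liver (Mus musculus) for metabolic stability, read by LC-MS, with a stated time of 1 h, tested at 5 uM (a lower number here means that less of the compound is left, a higher number that more of the compound is left), at 49% and sits well clear of the other two. Compound 3 `COc1cc(OC)cc(N2CCN(C(=O)c3oc(C)nc3-c3ccccc3F)CC2)c1` gives 16.6% in this read-out, and compound 1 `Cc1nc(-c2ccccc2)c(C(=O)N2CCN(c3cccc(Cl)c3)CC2)o1` gives 2% in it.

Compound 4 `Cc1nc(-c2ccccc2)c(C(=O)N2CCN(c3cc(Cl)cc(Cl)c3)CC2)o1` turns the 2-fluorophenyl of compound 2 into phenyl: hydrogen in place of fluoro on an aromatic carbon with hydrogen in place of fluoro on an aromatic carbon, ortho to a large group.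

Among the compounds with values here, no measured step isolates this change. Within the data shown here, the one single-place step, a number 32.4 percentage points lower from compound 2 to compound 3 (beyond the scatter) for 3,5-dimethoxyphenyl in place of 3,5-dichlorophenyl on an amine nitrogen in a ring, shows how far the number can move in this small set but says nothing direct about the fluoro group. Compound 4 shares its phenyl with compound 1, which at 2% lies far under compound 2 at 49% in the same read-out. Those two differ in more than one place, so that gap cannot be assigned to the fluoro group alone, and only part of it is carried over. A moderate fall is expected in this assay with wide uncertainty. The estimated change is a number 17 percentage points lower from compound 2 to compound 4 (beyond the scatter) as a working figure. For compound 4 the expected value is 32% within an estimated range of 12% to 52% for this measurement.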

Compound 4, percent of the compound remaining: 43.4%
For compound 4 the middle estimate is 11.4 percentage points below the measured one, within the range that was stated.
By their numbers in this assay, from the lowest: compound 1; then compound 3; then compounds 4 and 2 (each within the scatter of the next).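

In this assay, hydrogen in place of fluoro on an aromatic carbon, ortho to a large group, gives a number 5.6 percentage points lower from compound 2 to compound 4 (within the scatter), so with the 3,5-dichlorophenyl held fixed, the change from 2-fluorophenyl to phenyl cannot be told apart from the scatter. With the phenyl held fixed instead, chloro in place of hydrogen on an aromatic carbon of the aryl group on the ring nitrogen gives a number 41.4 percentage points higher from compound 1 to compound 4 (beyond the scatter), a large step that places a strong dependence of this read-out on that aryl group, whereas the fluoro position shows none in this one pair. No measurement on hand accounts for either step.

From the compounds shown here alone, the fluoro comparison rests on a single pair and a single aryl group on the ring nitrogen, so it remains open whether the same flat result holds alongside the 3,5-dimethoxyphenyl or with only one chloro present. Also open, going by these compounds, is what a different group on this aromatic carbon, such as trifluoromethyl, a nitrile or an amine, would do to the amount of compound left.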